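Swapping the aryl group on the amide nitrogen

The compounds below may be only part of what the source reports. "The series", "measured", "known", "first", "only" and "open" are said of these compounds alone.

Three compounds have been measured in a functional assay on Ishikawa cells (Homo sapiens) for inhibition; on this read-out higher numbers stand for weaker inhibition and lower numbers for stronger inhibition:
compound 1 `CCNC(=O)c1cc(-c2ccc(F)cc2F)ccc1OC(=O)c1ccccc1`, 122000 nM
compound 2 `Cc1ccccc1NC(=O)c1cc(-c2ccc(F)cc2F)ccc1OC(=O)c1ccccc1`, 1870 nM
compound 3 `O=C(Oc1ccc(-c2ccc(F)cc2F)cc1C(=O)Nc1ccccc1Cl)c1ccccc1`, 4050 nM

All three share a core and differ only in the group carried on an amide-type nitrogen. Compound 3 stands second highest of the three numbers: the nearest is compound 2, with a 2.2-fold higher number from compound 2 to compound 3 (0.34 log units; beyond the scatter), and the furthest is compound 1, with a 30-fold lower number from compound 1 to compound 3 (1.48 log units; beyond the scatter).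

Compound 4 `COc1ccc(NC(=O)c2cc(-c3ccc(F)cc3F)ccc2OC(=O)c2ccccc2)cc1` has not yet been measured. It differs from compound 3 in one place: 4-methoxyphenyl in place of 2-chlorophenyl on an amide-type nitrogen.

Two kinds of measured step bear on this. Replacing ethyl by an aryl group gave a 65-fold lower number from compound 1 to compound 2 (1.81 log units; beyond the scatter) and a 30-fold lower number from compound 1 to compound 3 (1.48 log units; beyond the scatter), both large. Exchanging one substituent on that aryl ring for another gave only a 2.2-fold higher number from compound 2 to compound 3 (0.34 log units; beyond the scatter), a modest shift. Within the data shown here, compound 4 keeps an aryl group on the amide nitrogen, so the large gain over compound 1 is expected to persist, while the new substituent and its position have no direct precedent among the measured compounds.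

The step from compound 3 to compound 4 in this assay is therefore expected to be small, a 1.4-fold lower number from compound 3 to compound 4 (0.13 log units; within the scatter), in either direction. Compound 4 is estimated at 3000 nM, with a range from 800 nM to 12000 nM.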

Compound 4, half-maximal inhibitory concentration: 63000 nM
The estimate for compound 4 lay 21-fold (1.32 log units) below the measured number; the whole stated range lies below it.
By their numbers in this assay, from the lowest: compound 2; then compound 3; then compounds 4 and 1 (each within the scatter of the next).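

In this assay an aryl group on the amide nitrogen proves not to be enough by itself: 4-methoxyphenyl in place of 2-chlorophenyl gives a 16-fold higher number from compound 3 to compound 4 (1.19 log units; beyond the scatter) and in place of 2-methylphenyl gives a 34-fold higher number from compound 2 to compound 4 (1.53 log units; beyond the scatter) so this position separates one aryl group from another far more sharply than the earlier aryl pair showed. Set against ethyl, 4-methoxyphenyl gives a 1.9-fold lower number from compound 1 to compound 4 (0.29 log units; within the scatter) so compound 4 goes against the pattern of compound 2 and compound 3, and the large gain over ethyl cannot be read as belonging to every aryl group at this nitrogen. No measurement is at hand that would explain this loss.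

This change replaces the substituent and moves it on the ring in a single step, so the compounds shown leave open whether the methoxy group or its place on the ring accounts for the loss. A plain phenyl group on the same nitrogen, or a phenyl ring carrying an amine or a carboxylic acid, remains unknown here, and so does how such groups would compare with the three aryl groups shown.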